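Compound 1 to Compound 4: A Changed Amide Aryl Group

The compounds below may be only part of what the source reports. "The series", "measured", "known", "first", "only" and "open" are said of these compounds alone.

Going by the values given here, compound 1 `CCN1CCN(c2cc(C)c3cc(NC(=O)c4ccccc4C)ccc3n2)CC1` is assessed in a functional assay on MCF7 cells (Homo sapiens) for antiproliferative activity, read by MTT assay, with a stated time of 72 h (on this read-out lower numbers stand for stronger inhibition and higher numbers for weaker inhibition), where compound 1 gives 10900 nM, the highest of the three numbers known here. Among the compounds with values here, compound 2 `Cc1cc(NCCN2CCN(C)CC2)nc2ccc(NC(=O)c3ccc(Cl)c(Cl)c3)cc12` gives 1700 nM and compound 3 `CCN(CC)CCNc1cc(C)c2cc(NC(=O)c3ccc(Cl)c(Cl)c3)ccc2n1` gives 1420 nM; the only measured step, a 1.2-fold lower number from compound 2 to compound 3 (0.08 log units; within the scatter), concerns the amine side chain and not the amide. Compound 4 `CCN1CCN(c2cc(C)c3cc(NC(=O)c4cccc(F)c4)ccc3n2)CC1` differs from compound 1 only at the amide: 3-fluorophenyl in place of 2-methylphenyl on a carbonyl carbon. Within the data shown here, no measured step touches this part of the molecule, and compound 2 and compound 3 each differ from compound 1 in more than one place, so no single step to them can be read. The expectation therefore rests on thin ground, and the step of a 1.8-fold lower number from compound 1 to compound 4 (0.26 log units; within the scatter) is estimated to be modest. For compound 4 the estimate is 6000 nM, with a range from 1500 nM to 25000 nM.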

Compound 4, half-maximal inhibitory concentration: 8920 nM
Beside the measured number, compound 4's estimate is 1.5-fold (0.17 log units) below it, within the range that was stated.
By their numbers in this assay, from the lowest: compounds 3 and 2 (each within the scatter of the next); then compounds 4 and 1 (each within the scatter of the next).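

Going by these compounds alone, the first measured step at the amide is a 1.2-fold lower number from compound 1 to compound 4 (0.09 log units; within the scatter). With the rest of the molecule held fixed, exchanging 2-methylphenyl for 3-fluorophenyl on a carbonyl carbon therefore does not separate the two compounds in this assay. Nothing available here offers an explanation for this result. As far as these compounds go, compound 2 and compound 3 differ from compound 1 in more than one place, so steps to them cannot be read, and the amide's share in their numbers stays open. Also open, from the compounds shown here alone, is how a pyridyl or cyclohexyl group on that carbonyl carbon would read.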